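Series notes: aryl group on the ring amine nitrogen

The compounds below may be only part of what the source reports. "The series", "measured", "known", "first", "only" and "open" are said of these compounds alone.

Measured compounds:
compound 1 `Nc1ccccc1NC(=O)c1ccc(CSC(=S)N2CCN(Cc3ccccn3)CC2)cc1`, 14.2%
compound 2 `Nc1ccccc1NC(=O)c1ccc(CSC(=S)N2CCN(c3ccncc3)CC2)cc1`, 77%
compound 3 `Nc1ccccc1NC(=O)c1ccc(CSC(=S)N2CCN(c3ccc(F)cc3)CC2)cc1`, 60.8%

In a functional assay on HeLa cells (Homo sapiens) for antiproliferative activity, read by CCK-8 assay, with a stated time of 72 h, tested at 2 uM (a higher number here means a stronger effect of the compound at the concentration tested, a lower number a weaker effect), compound 3 stands second highest of the three, with compound 2 nearest at a number 16.2 percentage points lower from compound 2 to compound 3 (beyond the scatter) and compound 1 furthest at a number 46.6 percentage points higher from compound 1 to compound 3 (beyond the scatter). Compound 4 `Nc1ccccc1NC(=O)c1ccc(CSC(=S)N2CCN(c3ncccn3)CC2)cc1` is not yet measured; the change from compound 3 is pyrimidin-2-yl in place of 4-fluorophenyl on an amine nitrogen in a ring. For the measured compounds named here, the steps that bear on it are a number 62.8 percentage points higher from compound 1 to compound 2 (beyond the scatter) and a number 46.6 percentage points higher from compound 1 to compound 3 (beyond the scatter), both large, showing that a six-membered aromatic ring placed directly on the ring nitrogen gives the higher numbers, and a number 16.2 percentage points lower from compound 2 to compound 3 (beyond the scatter), modest, where the ring with a hetero atom stands higher than the carbon-only ring. Compound 4 keeps a directly attached six-membered aromatic ring, now with two hetero atoms, so a small rise in this assay or a step within the scatter is expected. Compound 4 is therefore estimated at 68% (range 50% to 84%), the expected step being a number 7.2 percentage points higher from compound 3 to compound 4 (within the scatter).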

Compound 4, a percentage reported as inhibition, at one concentration (the size of the read-out at that concentration, not a potency): 52.2%
Compound 4: the middle estimate sits 15.8 percentage points above what was measured, within the range that was stated.
By their numbers in this assay, from the lowest: compound 1; then compounds 4 and 3 (each within the scatter of the next); then compound 2.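

In this assay, replacing 4-fluorophenyl with pyrimidin-2-yl gives a number 8.6 percentage points lower from compound 3 to compound 4 (within the scatter), so compound 4 goes against the earlier reading from compound 2 and compound 3 that a ring with hetero atoms stands higher than the carbon-only ring. The two rings with hetero atoms are not interchangeable at this position, with a number 24.8 percentage points lower from compound 2 to compound 4 (beyond the scatter), while the directly attached ring still stands well clear of (pyridin-2-yl)methyl, with a number 38 percentage points higher from compound 1 to compound 4 (beyond the scatter). No measured evidence bears on the cause of these steps. The compounds shown leave open whether pyridin-2-yl or pyridin-3-yl would stand with compound 2 or with compound 4. A benzyl group on the same nitrogen would also show whether the low value of compound 1 goes with the methylene link or with the pyridine ring.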